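This account rests on a few compounds, and the source may have more. Where it says the series, first, only, none or still open, it means among the compounds named here.

Measured so far:
compound 1 `c1ccc(-c2cccc3c2CCC3c2ncc[nH]2)nc1` – 1150 nM
compound 2 `c1cc(-c2ccn[nH]2)c2c(c1)C(c1ncc[nH]1)CC2` – 52 nM
compound 3 `Cc1c(OCC2=NCCN2)ccc(Cl)c1NS(C)(=O)=O` – 25 nM

In a functional assay on CHO cells for agonist activity at Alpha-1A adrenergic receptor (Homo sapiens), read by FLIPR and calcium flux (on this read-out higher numbers stand for an effect only at larger amounts of compound and lower numbers for an effect already at smaller amounts), compound 2 stands second highest of the three numbers: compound 3 sits nearest, and compound 1 lies furthest away, above it. Compound 4 `Cn1nccc1-c1cccc2c1CCC2c1ncc[nH]1` differs from compound 2 by methyl in place of hydrogen on an aromatic nitrogen; cut one bond further out, the change reads 1H-pyrazol-5-yl to 1-methyl-1H-pyrazol-5-yl. For the measured compounds named here, only one measured step touches this ring, a 22-fold lower number from compound 1 to compound 2 (1.34 log units; beyond the scatter), a large step, but it exchanged the whole ring rather than adding a group on its nitrogen. Going by the values given here, no measured step covers a methyl on an aromatic nitrogen, so the size of the step is uncertain; a moderate rise in the number, beyond the scatter, is expected as the more likely outcome. Compound 4 is therefore estimated at 150 nM (range 40 nM to 600 nM), an expected 2.9-fold higher number from compound 2 to compound 4 (0.46 log units; beyond the scatter).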

Compound 4, half-maximal effective concentration: 278 nM
For compound 4 the middle estimate is 1.9-fold (0.27 log units) below the measured one; the range from low to high includes it.
By their numbers in this assay, from the lowest: compound 3; then compound 2; then compound 4; then compound 1.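

In this assay methyl in place of hydrogen on an aromatic nitrogen gives a 5.3-fold higher number from compound 2 to compound 4 (0.73 log units; beyond the scatter) and so shows that the number responds to a group on this nitrogen. The 1-methyl-1H-pyrazol-5-yl group still keeps part of the gain over pyridin-2-yl, with a 4.1-fold lower number from compound 1 to compound 4 (0.62 log units; beyond the scatter) remaining. Nothing at hand gives a reason for either step. The compounds shown leave open how an ethyl group or a longer chain on this nitrogen would read, and whether a methyl on a ring carbon of the 1H-pyrazol-5-yl group would raise the number as far.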